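Trimming the Chain on the Aromatic Nitrogen

A few compounds are considered here, and "the series" means these few. Any claim that something is new, unique, unknown or untested is made for them only; others in the source may bear on it.

Of the compounds shown here, three sharing one core have been measured in an ADME assay on microsomes from liver (Rattus norvegicus) for metabolic stability, read by LC-MS, with a stated time of 1 h, at 37 degrees C, tested at 4 uM; on this read-out lower numbers stand for a less stable compound and higher numbers for a more stable compound. Compound 1 `Cn1sc2cc(OCc3cccc(-c4ccc(Cl)c(C(=O)O)c4)c3)ccc2c1=O`, with methyl on the aromatic nitrogen, gives 84%. Compound 2 `O=C(O)c1cc(-c2cccc(COc3ccc4c(=O)n(C5CCC5)sc4c3)c2)ccc1Cl`, with cyclobutyl there, gives 67%. Compound 3 `CC(C)CCn1sc2cc(OCc3cccc(-c4ccc(Cl)c(C(=O)O)c4)c3)ccc2c1=O`, with isopentyl, gives 92%. That places compound 3 level with compound 1 within the scatter and clearly apart from compound 2.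

Going by the values given here, compound 4 `CC(C)Cn1sc2cc(OCc3cccc(-c4ccc(Cl)c(C(=O)O)c4)c3)ccc2c1=O` changes only this group: isopropyl in place of isobutyl on a saturated chain carbon bound to an aromatic nitrogen. Put simply, the group on the aromatic nitrogen goes from isopentyl to isobutyl. Among the compounds with values here, no measured compound carries isobutyl, so the evidence is indirect.

Within the data shown here, two measured steps bear on the change. Going from methyl to isopentyl gave a number 8 percentage points higher from compound 1 to compound 3 (within the scatter), so these two ringless groups are not told apart by this assay. Going from cyclobutyl to isopentyl gave a number 25 percentage points higher from compound 2 to compound 3 (beyond the scatter), a larger step, but it replaces a ring with a chain, and compound 4 involves no such swap. Isobutyl has no ring, so it sides with methyl and isopentyl rather than cyclobutyl.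

The expected change is a number 5 percentage points lower from compound 3 to compound 4 (within the scatter), which would be no step beyond the scatter. The estimate for compound 4 is 87%, with an expected range of 75% to 96%.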

Compound 4, percent of the compound remaining: 86%
Compound 4: the middle estimate sits 1 percentage points above what was measured; low and high end bracket the measured number.
By their numbers in this assay, from the lowest: compound 2; then compounds 1, 4 and 3 (each within the scatter of the next).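

In this assay, cutting the chain on the aromatic nitrogen from isopentyl to isobutyl gives a number 6 percentage points lower from compound 3 to compound 4 (within the scatter), so this position tolerates the loss of one carbon from the chain without a change that can be told from the scatter. Isobutyl also stays level with methyl, with a number 2 percentage points higher from compound 1 to compound 4 (within the scatter), while the cyclobutyl compound stays apart, with a number 19 percentage points higher from compound 2 to compound 4 (beyond the scatter), which means that across these four compounds the three open-chain groups sit together and cyclobutyl, the only ring, is the one exception. Nothing available gives a reason for this split between the chains and the ring. 

A single ring cannot settle whether a cyclopropyl or a cyclohexyl group on this nitrogen would match cyclobutyl or the open chains, so the split may belong to rings in general or to cyclobutyl alone. Also open is the effect of a longer chain, or of a chain ending in an amine or a hydroxyl group, as the chains shown here stop at isopentyl and carry only carbon and hydrogen.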